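The source may report more compounds than this note shows. Statements on the series, on what has been measured and on what is new or still open speak of the compounds shown alone.

Measured compounds:
compound 1, `NCc1csc(NC(=O)c2ccc(Cl)cc2)n1`, 25 ug/mL
compound 2, `CC(C)(C)c1cc(C(=O)Nc2ccncc2)n(Cc2ccccc2)n1`, 6.3 ug/mL
compound 3, `NCc1csc(NC(=O)c2cn(Cc3ccccc3)nn2)n1`, 25 ug/mL

In a physicochemical assay for solubility, read by nephelometry, measured as kinetic solubility, at pH 6.5 (on this read-out lower numbers stand for lower solubility and higher numbers for higher solubility), compound 2 gives the lowest of the three numbers. Compound 1 gives 25 ug/mL and compound 3 gives 25 ug/mL, each of them beyond the scatter above compound 2. Compound 1 and compound 3 share the aminomethyl-bearing thiazole amide and differ only in the acyl part, and both sit at the same number in this assay.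

Compound 4, `CNCc1csc(NC(=O)c2cc(C(C)(C)C)nn2Cc2ccccc2)n1`, keeps the acyl part of compound 2 and changes the amide partner: 4-((methylamino)methyl)-1,3-thiazol-2-yl in place of pyridin-4-yl on an amide-type nitrogen. Going by the values given here, no measured pair shows exactly this exchange. What the data do show is that the two compounds carrying a thiazole of this kind, compound 1 and compound 3, stand above compound 2 in this assay, while compound 2 is the only one carrying a pyridin-4-yl.

On that basis the step from compound 2 to compound 4 is expected to go upward, a 3.2-fold higher number from compound 2 to compound 4 (0.50 log units; beyond the scatter), and to go beyond the scatter, because compound 1 at 25 ug/mL and compound 3 at 25 ug/mL both sit well above compound 2. Compound 4 is thus estimated at 20 ug/mL, within a range from 6 ug/mL to 60 ug/mL.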

Compound 4, solubility: 12.5 ug/mL
The estimate for compound 4 lay 1.6-fold (0.20 log units) above the measured number; low and high end bracket the measured number.
By their numbers in this assay, from the lowest: compounds 2, 4, 1 and 3 (each within the scatter of the next, the first and the last beyond it).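

Across the amide-type nitrogen of this acyl part, this assay gives a 2.0-fold higher number from compound 2 to compound 4 (0.30 log units; within the scatter) for 4-((methylamino)methyl)-1,3-thiazol-2-yl in place of pyridin-4-yl. Going by these compounds alone, this is the first step between measured compounds that differ in one place, and it shows that this exchange, with its larger group and its added hydrogen-bond donor and acceptors, does not separate the two compounds on this read-out beyond what repeated measurements would do. Nothing measured here offers an explanation for how closely the two compounds read.

The compounds shown leave open how much of the thiazole group counts at this position, for example whether a plain 1,3-thiazol-2-yl without the side chain, or one bearing a primary aminomethyl, a dimethylaminomethyl or a morpholine in place of the methylamino, would give a step beyond the scatter on this same acyl part. They also leave open whether a carboxylic acid on that side chain, or a change on the acyl part itself, such as a smaller alkyl group in place of the tert-butyl, would give a step beyond the scatter.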